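Dropping a methoxy from the aryl on the carbonyl carbon

A few compounds are considered here, and "the series" means these few. Any claim that something is new, unique, unknown or untested is made for them only; others in the source may bear on it.

Of the compounds shown here, three sharing one core have been tested in a functional assay on PC-3 cells (Homo sapiens) for cytotoxicity, read by sulforhodamine B assay, with a stated time of 48 h, tested at 1 uM; a higher number here means a weaker effect of the compound at the concentration tested, a lower number a stronger effect. Compound 1 `COc1cc(-c2cc(/C=C/C(=O)c3ccc(N)cc3)[nH]n2)cc(OC)c1OC` gives 76%. Compound 2 `COc1cc(-c2cc(/C=C/C(=O)c3ccc(Cl)c(Cl)c3)[nH]n2)cc(OC)c1OC` gives 87%, so that a number 11 percentage points higher from compound 1 to compound 2 (beyond the scatter). Compound 3 `COc1ccc(C(=O)/C=C/c2cc(-c3cc(OC)c(OC)c(OC)c3)n[nH]2)cc1OC` gives 71%, the lowest of the three numbers; its nearest neighbour is compound 1, since a number 5 percentage points lower from compound 1 to compound 3 (within the scatter), while against compound 2 the gap is wider, because a number 16 percentage points lower from compound 2 to compound 3 (beyond the scatter).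

The next compound, compound 4 `COc1ccc(C(=O)/C=C/c2cc(-c3cc(OC)c(OC)c(OC)c3)n[nH]2)cc1`, differs from compound 3 in one place: hydrogen in place of methoxy on an aromatic carbon. Within the data shown here, none of the measured steps removes a single methoxy; each of them swaps the whole aryl on the carbonyl carbon, and those swaps moved this assay by at most a modest amount. The present change is smaller than any of them, so only a small shift is expected, if any beyond the scatter, and its direction cannot be read from the three numbers. Compound 4 is therefore expected to give 76%, between 62% and 90%, which means an expected step of a number 5 percentage points higher from compound 3 to compound 4 (within the scatter).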

Compound 4, a percentage reported as activity, at one concentration (the size of the read-out at that concentration, not a potency): 76%
Compound 4: the middle estimate sits on the measured number at the digits printed, within the range that was stated.
By their numbers in this assay, from the lowest: compounds 3, 1 and 4 (each within the scatter of the next); then compound 2.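

Taking one methoxy off the 3,4-dimethoxyphenyl to leave 4-methoxyphenyl is the first change here that alters a single group on this aryl, and in this assay it gives a number 5 percentage points higher from compound 3 to compound 4 (within the scatter) and so leaves no shift that can be told from the scatter. The 4-methoxyphenyl also stays apart from the 3,4-dichlorophenyl, with a number 11 percentage points lower from compound 2 to compound 4 (beyond the scatter) on record, while methoxy in place of amino gives no change at the digits printed from compound 1 to compound 4 (within the scatter) and thus leaves the 3,4-dichlorophenyl as the only aryl of the four whose number stands apart from all the others. Nothing measured here bears on why the numbers fall this way.

On these data alone, whether a hydroxyl, a fluorine or an ethoxy on this aromatic carbon would move the number remains open, as does the effect of removing the remaining methoxy. All four numbers come from a single concentration in this assay and so speak only of a stronger or weaker effect at that concentration.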